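The source may hold more compounds than are shown below. What is called first, only, known or untested is meant among the compounds shown, and "the series" means these compounds.

In a functional assay on L5178Y cells (Mus musculus) for cytotoxicity, read by MTT assay; a lower number here means a stronger inhibitor, a higher number a weaker inhibitor:
- compound 1 `CC(=O)c1ccc(OCCCCN2CCN(c3cccnc3)CC2)cc1`: 69 nM
- compound 2 `CCC(C)(C)c1ccc(OCCCCN2CCN(c3cccnc3)CC2)cc1`: 9.23 nM
- compound 3 `CC(C)(C)c1ccc(OCCCCN2CCN(c3ncccn3)CC2)cc1`: 20.8 nM
- compound 4 `CC(C)(C)c1ccc(OCCCCN2CCN(c3cccnc3)CC2)cc1`: not yet measured

Compound 3 stands between the other two, with compound 2 lower and compound 1 higher, both gaps beyond the scatter. The next change is pyridin-3-yl in place of pyrimidin-2-yl on an amine nitrogen in a ring. Within the data shown here, no measured step covers this exchange. The only one, a 7.5-fold lower number from compound 1 to compound 2 (0.87 log units; beyond the scatter), is 1,1-dimethylpropyl in place of acetyl on an aromatic carbon, elsewhere in the molecule. Compound 2 already carries pyridin-3-yl and gives 9.23 nM, which hints at a slightly lower number in this assay. The expected step is a 1.5-fold lower number from compound 3 to compound 4 (0.17 log units; within the scatter), within the scatter. The estimate for compound 4 is 14 nM, with an expected range of 6 nM to 35 nM.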

Compound 4, half-maximal inhibitory concentration: 11.7 nM
Compound 4: middle estimate off by 1.2-fold (0.08 log units), on the high side; the measured number falls inside the stated range.
By their numbers in this assay, from the lowest: compounds 2, 4 and 3 (each within the scatter of the next, the first and the last beyond it); then compound 1.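

In this assay pyridin-3-yl in place of pyrimidin-2-yl on the amine nitrogen in a ring gives a 1.8-fold lower number from compound 3 to compound 4 (0.25 log units; within the scatter) with the tert-butyl group held fixed, so this exchange stays within the scatter. Hydrogen in place of methyl on the saturated chain gives a 1.3-fold higher number from compound 2 to compound 4 (0.10 log units; within the scatter) and also stays within the scatter, whereas tert-butyl in place of acetyl gives a 5.9-fold lower number from compound 1 to compound 4 (0.77 log units; beyond the scatter) and lies beyond it. Open, on these data alone, is how a phenyl group on that amine nitrogen, or a carboxylic acid on the aromatic carbon, would read in this assay and whether a longer chain would shift the number. No measurement shown here accounts for these steps.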